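Swapping the Aryl Group: What to Expect for Compound 4

This account rests on a few compounds, and the source may have more. Where it says the series, first, only, none or still open, it means among the compounds named here.

Compound 1, `O=C(/C=C\Nc1ccc(Cl)cc1)c1cn(-c2ccccc2)nc1-c1ccccc1`, gives 5200 nM.
Compound 2, `O=C(/C=C\Nc1ccc(O)cc1)c1cn(-c2ccccc2)nc1-c1ccccc1`, gives 3600 nM.
Compound 3, `COc1cc(N/C=C\C(=O)c2cn(-c3ccccc3)nc2-c2ccc(F)cc2)cc(OC)c1OC`, gives 4890 nM.

All three numbers come from a functional assay on PC-3 cells (Homo sapiens) for antiproliferative activity, read by MTT assay, with a stated time of 48 h; on this read-out higher numbers stand for weaker inhibition and lower numbers for stronger inhibition. Compound 3 sits among its two neighbours: its number lies within the usual scatter of both compound 1 and compound 2, so the three cannot be told apart on these data.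

Compound 4, `COc1cc(N/C=C\C(=O)c2cn(-c3ccccc3)nc2-c2cc(OC)c(OC)c(OC)c2)cc(OC)c1OC`, differs from compound 3 in one place: 3,4,5-trimethoxyphenyl in place of 4-fluorophenyl on an aromatic carbon. Going by the values given here, the only single-point step measured so far, a 1.4-fold lower number from compound 1 to compound 2 (0.16 log units; within the scatter), swaps a group on the aromatic ring attached to the nitrogen and leaves the ring changed here untouched. Among the compounds with values here, no measured step therefore bears on the change from compound 3 to compound 4, and the only guidance is that the three measured numbers all lie close together.

On that basis compound 4 is expected to give about 4500 nM in this assay, with a plausible range from 1500 nM to 13000 nM. The estimated step of a 1.1-fold lower number from compound 3 to compound 4 (0.04 log units; within the scatter) is thus expected to stay within the scatter, with no direction favoured.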

Compound 4, half-maximal inhibitory concentration: 14100 nM
Beside the measured number, compound 4's estimate is 3.1-fold (0.50 log units) below it; the whole stated range lies below it.
By their numbers in this assay, from the lowest: compounds 2, 3 and 1 (each within the scatter of the next); then compound 4.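

Going by these compounds alone, this is the only step so far that changes the aromatic group on the five-membered ring, next to the ring nitrogen, and swapping 4-fluorophenyl for 3,4,5-trimethoxyphenyl gives a 2.9-fold higher number from compound 3 to compound 4 (0.46 log units; beyond the scatter) in this assay and so points to weaker inhibition. Within the data shown here, the position therefore responds to what it carries, whereas the single change on the ring attached to the nitrogen, between compound 1 and compound 2, stayed within the scatter. No measurement here offers a reason for this shift.

As far as these compounds go, the change replaces a whole aryl group at once, so it remains open whether a single methoxy group on that ring would give the same shift, or how an amine or a carboxylic acid there would behave. From the compounds shown here alone, it is also open whether the shift would hold with a different ring on the nitrogen, such as the 4-chlorophenyl of compound 1.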